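A few compounds are considered here, and "the series" means these few. Any claim that something is new, unique, unknown or untested is made for them only; others in the source may bear on it.

The account follows compound 1 `NC(=O)c1ccc(N(Cc2ccc(C3CCCCC3)cn2)C(=O)[C@H]2CCN2S(=O)(=O)c2c(F)c(F)c(F)c(F)c2F)c(F)c1` to compound 4 `O=C1NCc2cc(N(Cc3ccc(C4CCCCC4)cn3)C(=O)[C@H]3CCN3S(=O)(=O)c3c(F)c(F)c(F)c(F)c3F)c(F)cc21`. In a functional assay on MDA-MB-231 cells (Homo sapiens) for antiproliferative activity, with a stated time of 72 h (on this read-out higher numbers stand for an effect only at larger amounts of compound and lower numbers for an effect already at smaller amounts), compound 1 gives "not determined" (no result reported), so compound 1 stands nowhere on the numbers shown and has no value of its own to start from. The change is a group of 11 heavy atoms (8 carbon, 1 nitrogen, 1 oxygen, 1 fluorine; one five-membered non-aromatic ring with 1 hetero atom, one six-membered aromatic ring of carbon only) in place of a group of 10 heavy atoms (7 carbon, 1 nitrogen, 1 oxygen, 1 fluorine; one six-membered aromatic ring of carbon only), on an amide-type nitrogen. Two measured compounds offer a footing. For the measured compounds named here, compound 2 `O=C([C@H]1CCN1S(=O)(=O)c1c(F)c(F)c(F)c(F)c1F)N(Cc1ccc(C2CCCCC2)cc1)c1ccc2c(=O)[nH]ccc2c1` gives 1400 nM in this assay, and compound 3 `O=C([C@H]1CCN1S(=O)(=O)c1c(F)c(F)c(F)c(F)c1F)N(Cc1ccc(C2CCCCC2)cc1)c1ccc2c(=O)[nH]ncc2c1` gives 1600 nM; the single measured step, a 1.1-fold higher number from compound 2 to compound 3 (0.06 log units; within the scatter), exchanges one two-ring group for another on an amide-type nitrogen and does not touch the change from compound 1 to compound 4. Going by the values given here, no measured step therefore bears directly on it, and with no number for compound 1 neither direction nor size of the step can be read off. What remains is that compounds 2 and 3, carrying on the same amide-type nitrogen a group with a six-membered aromatic ring of carbon only fused to a second ring, both fall near the same level. On that footing compound 4 is expected to give about 1500 nM in this assay, estimated between 400 nM and 6000 nM.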

Compound 4, half-maximal effective concentration: 2000 nM
The estimate for compound 4 lay 1.3-fold (0.12 log units) below the measured number, within the range that was stated.
By their numbers in this assay, from the lowest: compounds 2, 3 and 4 (each within the scatter of the next).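

In this assay, for the compounds shown here, compound 1 gives "not determined" (no result reported), so no step to compound 4 can be read from this result. The compounds shown leave open how exchanging the 4-carbamoyl-2-fluorophenyl group alters the number. No supporting data at hand bear on the value of compound 4.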